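The compounds below may be only part of what the source reports. "The series", "measured", "known", "first", "only" and "open" are said of these compounds alone.

Measured compounds:
Compound 1 `CN1CCN(CCCNCc2cn(-c3ccc([N+](=O)[O-])cc3)nc2-c2ccc(Cl)cc2)CC1` gives 3700 nM in an ADME assay on Huh-7 cells (Homo sapiens) for cytotoxicity; a lower number here means that less compound is tolerated, a higher number that more compound is tolerated.
Compound 2 `CN1CCN(CCNCc2cn(-c3ccc(F)cc3F)nc2Cc2ccccc2)CC1` reaches only the limit of > 20000 nM in this assay, a bound of the assay and not a number.
Compound 3 `Cc1ccccc1-c1nn(-c2ccccc2Cl)cc1CNCCN1CCN(C)CC1` likewise reaches only the limit of > 20000 nM in this assay, again a bound rather than a number.

Going by the values given here, compound 2 therefore stands at the limit of > 20000 nM in this assay, at which 2 of the 3 values shown sit; compound 1 is the one compound of the three that gives an actual number, and it lies below that bound. No pair of these compounds differs in a single place, so no measured step is available to set a scale.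

Compound 4 `Cc1cccc(-c2nn(-c3ccc(F)cc3F)cc2CNCCN2CCN(C)CC2)c1` is the unmeasured compound. It differs from compound 2 by 3-methylphenyl in place of benzyl on an aromatic carbon. Compound 3 also carries a methylphenyl group directly on the shared core and sits at the limit, which is the only hint the data offer for this kind of change.

With nothing measured to suggest otherwise, the step from compound 2 to compound 4 in this assay is expected to be none beyond the scatter, so that a number no higher from compound 2 to compound 4 (the limit leaves the size open) is the estimated step. Compound 4 is accordingly expected to give about 20000 nM in this assay, within 8000 nM to 40000 nM, and most likely to be reported only as a limit.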

Compound 4, half-maximal cytotoxic concentration: > 20000 nM
Compound 4 was reported as a limit; the forecaster's own chance of this, stated with the estimate: 70%; the middle value sits exactly at the limit.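

Compound 2 and compound 4 both reach only a limit in this assay, so no step can be read between them: the limit of > 20000 nM in this assay, at which 3 of the 4 values shown sit.

The compounds shown leave open whether 3-methylphenyl in place of benzyl on an aromatic carbon changes the half-maximal cytotoxic concentration at all, and, if it does, in which direction and by how much.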